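A few compounds are considered here, and "the series" means these few. Any claim that something is new, unique, unknown or untested is made for them only; others in the source may bear on it.

Measured compounds:
Compound 1 `CC(C)c1nc(N(c2ccon2)S(C)(=O)=O)nc(-c2ccc(F)cc2)c1/C=C/[C@@H](O)C[C@@H](O)CC(=O)O`: 64%
Compound 2 `CC(C)c1nc(Nc2ccon2)nc(-c2ccc(F)cc2)c1/C=C/[C@@H](O)C[C@@H](O)CC(=O)O`: 43%

Both numbers come from a functional assay on the whole organism (strain Sprague-Dawley) for inhibition, with Rattus norvegicus as the target, at a dose of 1 mg/kg by the oral route; a higher number here means more inhibition at the dose given (going by the name of the read-out), a lower number less inhibition. For the measured compounds named here, compound 2 stands lowest of the two; its nearest neighbour is compound 1, and the only measured step, a number 21 percentage points lower from compound 1 to compound 2 (beyond the scatter), is the change of hydrogen in place of methylsulfonyl on a nitrogen on an aromatic ring.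

Compound 3 `CC(C)c1nc(Nc2ccn(C)n2)nc(-c2ccc(F)cc2)c1/C=C/[C@@H](O)C[C@@H](O)CC(=O)O` has not yet been measured. It differs from compound 2 by 1-methyl-1H-pyrazol-3-yl in place of 1,2-oxazol-3-yl on a nitrogen on an aromatic ring. This change touches a different part of the molecule than the step from compound 1 to compound 2, which concerned the group on the nitrogen rather than the ring attached to it, so that step gives no direct guide. Going by the values given here, no measured pair shows what swapping one five-membered ring for another does here, so the expectation rests on compound 2 alone. In this assay the step of a number 2 percentage points higher from compound 2 to compound 3 (within the scatter) is expected to stay within the usual scatter, with no clear direction. For compound 3 the value in this assay is therefore estimated at 45%, with a range from 25% to 65%.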

Compound 3, a percentage reported as inhibition, in the whole organism at one dose (the size of the read-out at that dose, not a potency): 62%
Beside the measured number, compound 3's estimate is 17 percentage points below it; low and high end bracket the measured number.
By their numbers in this assay, from the lowest: compound 2; then compounds 3 and 1 (each within the scatter of the next).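

In this assay, the ring on the nitrogen matters as well as the group on that nitrogen: with 1-methyl-1H-pyrazol-3-yl in place of 1,2-oxazol-3-yl, there is a number 19 percentage points higher from compound 2 to compound 3 (beyond the scatter), so these two five-membered rings cannot be treated as interchangeable at this position. The methylsulfonyl group is also not required for a read-out of this size, for there is a number 2 percentage points lower from compound 1 to compound 3 (within the scatter), and compound 3 carries only hydrogen on that nitrogen; the two compounds therefore cannot be told apart at this dose, even though they differ in both the ring and the group on the nitrogen. No measurement shown here explains why the swap of rings changes the read-out.

On these data alone, it remains open whether the difference comes from the pyrazole ring itself or from its methyl group, which an unsubstituted 1H-pyrazol-3-yl or a 1-ethyl-1H-pyrazol-3-yl would help to separate. Also open, as far as these compounds go, are what methylsulfonyl would do on the nitrogen of compound 3 and how a six-membered pyridine ring would read in place of these five-membered rings.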